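Cytotoxicity tolerance of hydrazone compounds on HeLa cells

The source may hold more compounds than are shown below. What is called first, only, known or untested is meant among the compounds shown, and "the series" means these compounds.

Compound 1 `Cc1ccc(/C=N/N(C(=O)c2ccccc2)C(=O)c2ccncc2)cc1` was tested in an ADME assay on HeLa cells (Homo sapiens) for cytotoxicity (a higher number here means that more compound is tolerated, a lower number that less compound is tolerated), and gives 100 ug/mL. Compound 3 `COc1cccc(OC)c1/C=N/NC(=O)c1ccncc1` gives 100 ug/mL in this assay. On these numbers compound 1 sits level with compound 3, with no difference beyond the scatter. Compound 2 `O=C(N/N=C/c1c[nH]c2ccccc12)c1ccncc1` reaches only a limit of this assay, >= 100 ug/mL, so no number is known for it. That limit is the one at which one of the three values sits (the limit of >= 100 ug/mL in this assay, at which 1 of the 3 values shown sits).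

Compound 4 `COc1cc(/C=N/N(C(=O)c2ccccc2)C(=O)c2ccncc2)ccc1O` has not yet been measured in this assay. It differs from compound 1 in one place: 4-hydroxy-3-methoxyphenyl in place of 4-methylphenyl on a carbon with a double bond to nitrogen. Going by the values given here, no measured pair among compounds 1, 2 and 3 shows a step of this kind, so the effect of the change can only be estimated from where compound 1 stands. The step is expected to be small, none beyond the scatter, as no change at the digits printed from compound 1 to compound 4 (within the scatter). Compound 4 is therefore estimated to give about 100 ug/mL in this assay, with a range from 50 ug/mL to 200 ug/mL.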

Compound 4, minimum cytotoxic concentration: 100 ug/mL
For compound 4 middle estimate and measured number coincide at the digits printed; the range from low to high includes it.
By their numbers in this assay, from the lowest: compounds 1, 3 and 4 (each within the scatter of the next).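

Going by these compounds alone, until now, no measured pair showed what a change at this position does, on a carbon with a double bond to nitrogen. With 4-hydroxy-3-methoxyphenyl in place of 4-methylphenyl, the result in this assay is no change at the digits printed from compound 1 to compound 4 (within the scatter), so the larger ring substituent, which brings 1 hydrogen-bond donor and 2 hydrogen-bond acceptors, is tolerated here as well as the simple 4-methylphenyl group. This reading rests on a single step, and compound 2 shows that the assay reaches a limit in this same region: the limit of >= 100 ug/mL in this assay, at which 1 of the 4 values shown sits.

Going by these compounds, whether a different kind of group at this position, such as an amine or a carboxylic acid, would move the tolerated concentration remains open. So does whether the same change would give the same result on the core of compound 3.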